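A Fluorine for a Methyl on the Benzylamide Arm

A few compounds are considered here, and "the series" means these few. Any claim that something is new, unique, unknown or untested is made for them only; others in the source may bear on it.

Of the compounds shown here, two sharing one core have been tested in a functional assay on A549 cells (Homo sapiens) for cytotoxicity, read by MTT assay, with a stated time of 24 h; a higher number here means a weaker inhibitor, a lower number a stronger inhibitor. Compound 1 `C=CC1=C(C(=O)NCc2ccccc2)C(c2ccc(OC)cc2)OC1` carries a plain benzyl group on its amide nitrogen. In this assay compound 1 reaches only the limit of > 100000 nM, so no number is known for it. Compound 2 `C=CC1=C(C(=O)NCc2ccc(C)cc2)C(c2ccc(F)cc2)OC1` carries a 4-methylbenzyl group on the amide nitrogen and differs from compound 1 in both aryl groups. In this assay compound 2 likewise stops at the limit of > 100000 nM. Both results sit at the limit of > 100000 nM in this assay, at which 2 of the 2 values shown sit, and compound 2 stands there with no measured number of its own. Compound 3 `C=CC1=C(C(=O)NCc2ccccc2F)C(c2ccc(F)cc2)OC1` differs from compound 2 in one place: 2-fluorophenyl in place of 4-methylphenyl on a saturated chain carbon bound to an amide-type nitrogen. With compound 2 giving only a limit, no step beyond the scatter in either direction can be foreseen, and the expected step from compound 2 to compound 3 is a step that the limit leaves unreadable from compound 2 to compound 3. Compound 3 is estimated at 200000 nM, within 50000 nM to 1000000 nM.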

Compound 3, half-maximal inhibitory concentration: > 100000 nM
Compound 3 was reported as a limit; the forecaster's own chance of this, stated with the estimate: 80%; the middle value lies beyond the limit too.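

Compound 3 gives > 100000 nM in this assay, which is a limit and not a number. Among these compounds, compound 2 also gives only a limit, so no step from compound 2 to compound 3 can be read. Whether any change to the shared core would give a measured value remains open: the limit of > 100000 nM in this assay, at which 3 of the 3 values shown sit.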